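A few compounds are considered here, and "the series" means these few. Any claim that something is new, unique, unknown or untested is made for them only; others in the source may bear on it.

Compounds measured so far in an assay on HEK293 cells for negative allosteric modulation of metabotropic glutamate receptor 5 (Homo sapiens), read by FLIPR; a higher number here means a weaker inhibitor, a lower number a stronger inhibitor:

compound 1, `COC1CCN(C(=O)N2CC(c3nc(-c4cccc(Cl)c4)no3)C2)CC1`: > 10000 nM
compound 2, `O=C(c1ccc(Cl)cc1)N1CC(c2nc(-c3cccc(F)c3)no2)C1`: > 10000 nM
compound 3, `O=C(C1CCC(F)(F)CC1)N1CC(c2nc(-c3cccc(F)c3)no2)C1`: > 10000 nM

Each of these three values is a limit of the assay rather than a number. From the compounds shown here alone, compound 1 stands at the limit of > 10000 nM in this assay, at which 3 of the 3 values shown sit, so how weak it truly is remains open. Among the compounds with values here, the only comparison between two measured compounds is a step that the two limits leave unreadable from compound 2 to compound 3, and because the limit of > 10000 nM in this assay, at which 3 of the 3 values shown sit, holds both of them, its size cannot be read.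

Compound 4 is `O=C(C1CCCO1)N1CC(c2nc(-c3cccc(Cl)c3)no2)C1`. It differs from compound 1 in one place: oxolan-2-yl in place of 4-methoxypiperidin-1-yl on a carbonyl carbon. Within the data shown here, no measured step follows this exact change. The step from compound 2 to compound 3 also swaps the group on the carbonyl carbon, but it is unreadable, so it gives no size and no direction to borrow. What the data show is three compounds that all stay at the limit, and nothing that points to a step beyond the scatter.

Compound 4 is therefore expected to sit at about 15000 nM in this assay, with a range of 5000 nM to 50000 nM. The expected step that the limit leaves unreadable from compound 1 to compound 4 starts from a limit and is estimated as no change beyond the scatter, most likely ending as another limit.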

Compound 4, half-maximal inhibitory concentration: 890 nM
Estimate against measurement, compound 4: 17-fold (1.23 log units) above; measured number below the stated range.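

Putting oxolan-2-yl in place of 4-methoxypiperidin-1-yl on a carbonyl carbon gives an at least 11-fold lower number from compound 1 to compound 4 (1.05 log units; beyond the scatter) in this assay, so the group at this place can decide whether the series shows a measurable value at all. The value of compound 1, > 10000 nM, is a limit of the assay and not a number. Compound 4 is the only compound shown with a number, and the other three values stay at one limit, which also leaves the steps among those compounds unreadable: the limit of > 10000 nM in this assay, at which 3 of the 4 values shown sit.

This single change swaps a six-membered ring for a five-membered one, removes the ring nitrogen from the place on the carbonyl carbon and lowers the heavy-atom count, and the compounds shown cannot separate these differences, since they include no close relative of oxolan-2-yl such as a cyclopentyl ring, a tetrahydropyran ring or an open methoxyethyl chain. From the compounds shown here alone, it also remains open whether oxolan-2-yl would give a similar result alongside the fluorophenyl group of compound 3, rather than the chlorophenyl group of compound 4.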